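Replacing one methoxy group with three on a shared core

A few compounds are considered here, and "the series" means these few. Any claim that something is new, unique, unknown or untested is made for them only; others in the source may bear on it.

Of the compounds shown here, three share one core and have been measured in a functional assay on A549 cells (Homo sapiens) for cytotoxicity, read by MTT assay, with a stated time of 48 h; on this read-out lower numbers stand for stronger inhibition and higher numbers for weaker inhibition. Compound 1 `COc1cc(-c2cc(C(=O)Nc3nc4ccc(Cl)cc4s3)nc3cc(-c4ccccc4)nn23)cc(OC)c1OC` gives 18200 nM, and compound 2 `COc1cc(-c2cc(C(=O)Nc3nc4ccc(F)cc4s3)nc3cc(-c4ccccc4)nn23)cc(OC)c1OC` gives 22400 nM. Among the measured compounds shown here, the only step between compounds that differ in a single place is a 1.2-fold higher number from compound 1 to compound 2 (0.09 log units; within the scatter). Compound 3 `COc1ccc(-c2cc(C(=O)Nc3nc4ccc(OC)cc4s3)nc3cc(-c4ccccc4)nn23)cc1` gives 17400 nM, the lowest of the three numbers, though each of the others sits within the scatter of it, so no order can be read from them.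

Compound 4 `COc1ccc2nc(NC(=O)c3cc(-c4cc(OC)c(OC)c(OC)c4)n4nc(-c5ccccc5)cc4n3)sc2c1` has not been measured. It differs from compound 3 by 3,4,5-trimethoxyphenyl in place of 4-methoxyphenyl on an aromatic carbon. For the measured compounds named here, no measured step touches this place, so no direct guide exists. What the numbers do show is that compounds 1 and 2 already carry the entering 3,4,5-trimethoxyphenyl group and fall within the scatter of compound 3, which carries 4-methoxyphenyl. On that basis no shift beyond the scatter is expected, and the estimated step is a 1.1-fold higher number from compound 3 to compound 4 (0.04 log units; within the scatter). Compound 4 is therefore expected to give about 19000 nM, with a likely range from 8000 nM to 45000 nM.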

Compound 4, half-maximal inhibitory concentration: 2810 nM
The estimate for compound 4 lay 6.8-fold (0.83 log units) above the measured number; measured number outside the range, below it.
By their numbers in this assay, from the lowest: compound 4; then compounds 3, 1 and 2 (each within the scatter of the next).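

In this assay, among the compounds shown here, 3,4,5-trimethoxyphenyl in place of 4-methoxyphenyl gives a 6.2-fold lower number from compound 3 to compound 4 (0.79 log units; beyond the scatter) and is the first change to reach beyond the scatter, so the group on this aromatic carbon can matter. With 3,4,5-trimethoxyphenyl held fixed, a second place matters too: methoxy in place of fluoro gives an 8.0-fold lower number from compound 2 to compound 4 (0.90 log units; beyond the scatter) and methoxy in place of chloro gives a 6.5-fold lower number from compound 1 to compound 4 (0.81 log units; beyond the scatter) even though the step between those two halogens stays within the scatter. Nothing at hand explains either shift.

For the compounds shown here, open is whether the gain from 3,4,5-trimethoxyphenyl would also appear alongside chloro or fluoro, since the step is seen only with methoxy at the second place. Also open, going by these compounds, is how an amine or a hydroxy group would behave at either place, or whether a single methoxy group on a phenyl ring with a different arrangement would do as well.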